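Isopropyl for Methylsulfanyl: a Small Shift Expected

This account rests on a few compounds, and the source may have more. Where it says the series, first, only, none or still open, it means among the compounds named here.

Compound 1 `CCCc1cc(N)c2cc(NC(=O)/C=C/c3ccc(SC)cc3)ccc2n1` was tested in a functional assay on HEK293 cells for activation of melanin-concentrating hormone receptor 1 (Homo sapiens), read by inositol phosphate accumulation (a higher number here means that more compound is needed for the effect, a lower number that less compound is needed), where compound 1 gives 71 nM. For the measured compounds named here, this is the smaller of the two numbers measured so far, yet compound 2 `Cc1cc(N)c2cc(NC(=O)/C=C/c3ccc(C(F)(F)F)cc3)ccc2n1`, which gives 140 nM, lies within the usual scatter of it, so the two cannot be told apart. Compound 3 `CCCc1cc(N)c2cc(NC(=O)/C=C/c3ccc(C(C)C)cc3)ccc2n1` differs from compound 1 in one place: isopropyl in place of methylsulfanyl on an aromatic carbon. Going by the values given here, no measured pair shows this change, so nothing about its effect is known. The step of a 1.3-fold higher number from compound 1 to compound 3 (0.10 log units; within the scatter) is expected to be small, at most about the size of the scatter. Compound 3 is therefore estimated at 90 nM, within 35 nM to 250 nM.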

Compound 3, half-maximal effective concentration: 520 nM
Beside the measured number, compound 3's estimate is 5.8-fold (0.76 log units) below it; the whole stated range lies below it.
By their numbers in this assay, from the lowest: compounds 1 and 2 (each within the scatter of the next); then compound 3.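

In this assay, isopropyl in place of methylsulfanyl gives a 7.3-fold higher number from compound 1 to compound 3 (0.86 log units; beyond the scatter), so more of compound 3 is needed for the same effect. For the compounds shown here, this is the first single-place comparison here, and it shows that the group on this aromatic carbon, para to a large group, matters: these two groups are not interchangeable. No measurement here gives a reason for the step. Still open, as far as these compounds go, is whether methoxy or chlorine at this place would stay close to compound 1 or move like isopropyl. Also open, from the compounds shown here alone, is how ethylsulfanyl would behave.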